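A few compounds are considered here, and "the series" means these few. Any claim that something is new, unique, unknown or untested is made for them only; others in the source may bear on it.

Measured compounds:
Compound 1 `O=[N+]([O-])c1ccc(-c2nc3cc(C(F)(F)F)ccc3n2C2CCCCC2)cc1` gives > 100000 nM in an ADME assay on Vero cells (Chlorocebus sabaeus) for cytotoxicity (on this read-out higher numbers stand for lower toxicity in this test and lower numbers for higher toxicity in this test), which is a limit of the assay and not a number.
Compound 2 `Nc1ccc(-c2nc3cc(C(F)(F)F)ccc3n2C2CCCCC2)cc1` gives > 100000 nM in this assay, again a limit rather than a number.
Among the measured compounds shown here, compound 3 `COc1ccc(-c2nc3cc(C(F)(F)F)ccc3[nH]2)c([N+](=O)[O-])c1` gives 20000 nM in this assay, the only real number here.

Compound 2 differs from compound 1 by amino in place of nitro on an aromatic carbon. The step that the two limits leave unreadable from compound 1 to compound 2 cannot be read because both readings sit at the limit of > 100000 nM in this assay, at which 2 of the 3 values shown sit. So the one measured example of this change tells nothing about its size.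

Compound 4 `COc1ccc(-c2nc3cc(C(F)(F)F)ccc3[nH]2)c(N)c1` has not been measured. It differs from compound 3 by amino in place of nitro on an aromatic carbon. This is the same kind of change as that from compound 1 to compound 2, but not the same change: in compound 1 the changed carbon is para to a large group, while in compound 3 it is ortho to a large group and meta to a methoxy group. The difference between the two cores is not broken down here.

Compound 3 starts from a real number, so a shift from it could be visible. The earlier example of the change sets no size, and the two limits show only that toxicity stayed low there. In this assay a step of about a 2.0-fold higher number from compound 3 to compound 4 (0.30 log units; within the scatter) is therefore expected, with wide uncertainty. Compound 4 is estimated at 40000 nM, somewhere between 12000 nM and 130000 nM.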

Compound 4, half-maximal cytotoxic concentration: 50000 nM
Compound 4: the middle estimate sits 1.3-fold (0.10 log units) below what was measured, and the stated range covers the measured number.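

In this assay, putting amino in place of nitro on the core of compound 3 gives a 2.5-fold higher number from compound 3 to compound 4 (0.40 log units; beyond the scatter), a modest shift that on this read-out points towards lower toxicity in this test. The same change on the core of compound 1 cannot be read, because both members of that pair give only a limit and not a number: the limit of > 100000 nM in this assay, at which 2 of the 4 values shown sit. So the series offers one readable example of this change, which shows its size on a single core, in a place ortho to a large group and meta to a methoxy group; it does not show that the same size would appear on the core of compound 1 or on any other core, and the two limits neither support nor contradict it.

The compounds shown leave open how a carboxylic acid or a nitrile in that same place would read in this assay, which would show whether the shift is particular to amino or also appears with other groups. Also open, on these data alone, is whether the step would keep its size with a longer chain such as ethoxy in place of the methoxy group.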